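Bromo to Iodo, Repeated on a Chloro-Bearing Core

This account rests on a few compounds, and the source may have more. Where it says the series, first, only, none or still open, it means among the compounds named here.

Compound 1 `Nc1scc(-c2ccc(Br)cc2)c1C(=O)c1ccccc1` serves as the reference. In a functional assay on CHO cells for agonist activity at adenosine receptor A1 (Homo sapiens), read by fluorescence and ERK phosphorylation, with stated times of 30 min and 1.5 h, tested at 10 uM (on this read-out lower numbers stand for a weaker effect and higher numbers for a stronger effect at the one concentration tested), compound 1 gives 49%. Compound 2 `Nc1scc(-c2ccc(I)cc2)c1C(=O)c1ccccc1` differs from it by iodo in place of bromo on an aromatic carbon; in this assay compound 2 gives 50%, so that a number 1 percentage points higher from compound 1 to compound 2 (within the scatter). Compound 3 `Nc1scc(-c2ccc(Br)cc2)c1C(=O)c1ccc(Cl)cc1` carries the second core, which differs from the core of compound 1 by chloro in place of hydrogen on an aromatic carbon; in this assay compound 3 gives 46%, and a number 3 percentage points lower from compound 1 to compound 3 (within the scatter). Compound 4 `Nc1scc(-c2ccc(I)cc2)c1C(=O)c1ccc(Cl)cc1` has not been measured; it differs from compound 3 by iodo in place of bromo on an aromatic carbon, the same change as that between compound 1 and compound 2, at the same place, and it occurs twice among these four compounds. Because the earlier step of a number 1 percentage points higher from compound 1 to compound 2 (within the scatter) stayed within the scatter, the corresponding step is expected to be a number 1 percentage points higher from compound 3 to compound 4 (within the scatter). Compound 4 is accordingly estimated at 47%, between 37% and 57%.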

Compound 4, a percentage reported as activity, at one concentration (the size of the read-out at that concentration, not a potency): 61%
Estimate against measurement, compound 4: 14 percentage points below, outside the stated range (above it).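

In this assay, iodo in place of bromo gives a number 15 percentage points higher from compound 3 to compound 4 (beyond the scatter), and chloro in place of hydrogen gives a number 11 percentage points higher from compound 2 to compound 4 (beyond the scatter). Set beside its earlier counterpart, the iodo change does not differ between the two cores by more than such pairs of steps can scatter: the same change on two cores in this assay, a number 1 percentage points higher (within the scatter) from compound 1 to compound 2 and a number 15 percentage points higher (beyond the scatter) from compound 3 to compound 4, 14 percentage points apart, within the scatter of two such steps. The chloro change reads the same way, so these four compounds neither show that either change depends on the core nor prove that it carries over unchanged: the same change on two cores in this assay, a number 3 percentage points lower (within the scatter) from compound 1 to compound 3 and a number 11 percentage points higher (beyond the scatter) from compound 2 to compound 4, 14 percentage points apart, within the scatter of two such steps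

The compounds shown leave open whether the steps would hold with an amine or a methoxy group in place of the halogen. Each value also stands for a single concentration, and a stronger or weaker effect is shown only at that concentration.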